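Swapping the aryl group on a weak beta-lactam pair

The source may report more compounds than this note shows. Statements on the series, on what has been measured and on what is new or still open speak of the compounds shown alone.

Of the compounds shown here, two of one shared core have been measured in a functional assay on MCF7 cells (Homo sapiens) for antiproliferative activity, read by MTT assay, with stated times of 24 h and 72 h; a higher number here means a weaker inhibitor, a lower number a stronger inhibitor. Compound 1 `COc1cc(N2C(=O)[C@@H](Oc3ccccc3)[C@H]2c2ccc([N+](=O)[O-])cc2)cc(OC)c1OC` gives 63000 nM. Compound 2 `COc1cc(N2C(=O)[C@@H](Oc3ccccc3)[C@H]2c2ccc([S+](C)[O-])cc2)cc(OC)c1OC` gives 20000 nM, and the step of a 3.2-fold lower number from compound 1 to compound 2 (0.50 log units; beyond the scatter) separates them. Among the compounds with values here, on these two numbers compound 2 stands as the lower one, the only neighbour being compound 1.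

Compound 3 `COc1cc(N2C(=O)[C@@H](Oc3ccccc3)[C@H]2c2cc(N)c(OC)c(O)c2)cc(OC)c1OC` differs from compound 2 by the change (a group of 10 heavy atoms (7 carbon, 1 nitrogen, 2 oxygen; one six-membered aromatic ring of carbon only) in place of a group of 9 heavy atoms (7 carbon, 1 oxygen, 1 sulfur; one six-membered aromatic ring of carbon only), on a saturated ring carbon). Within the data shown here, no measured step concerns this kind of exchange; the step from compound 1 to compound 2 touches the same place but swaps different groups, so it only shows that the aryl group there can move this assay by a modest amount. He therefore expects a step of uncertain direction, a 1.7-fold lower number from compound 2 to compound 3 (0.22 log units; within the scatter), with a wide range. His estimate for compound 3 in this assay is 12000 nM, between 2500 nM and 60000 nM.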

Compound 3, half-maximal inhibitory concentration: 8800 nM
Estimate against measurement, compound 3: 1.4-fold (0.13 log units) above; measured number inside the range.
By their numbers in this assay, from the lowest: compound 3; then compound 2; then compound 1.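

In this assay the aryl group on a saturated ring carbon of the four-membered ring now gives a second step beyond the scatter, a 2.3-fold lower number from compound 2 to compound 3 (0.36 log units; beyond the scatter), so this position answers to a more extensive change of that group as well as to the first exchange. The span across the three compounds widens to a 7.2-fold lower number from compound 1 to compound 3 (0.85 log units; beyond the scatter), and compound 3, whose aryl group carries amine, methoxy and hydroxyl groups, has the lowest number of the three. Nothing available here accounts for this fall.

The amine, methoxy and hydroxyl groups enter together, so the compounds shown cannot tell which of them, if any, carries the step. They also leave open how a carboxylic acid or a fluorine atom on this aryl group would read in this assay at this position.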